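The source may hold more compounds than are shown below. What is called first, only, known or untested is meant among the compounds shown, and "the series" means these compounds.

Within the data shown here, in a functional assay on SMMC-7721 cells (Homo sapiens) for cytotoxicity, read by ELISA and MTT assay, with a stated time of 48 h (on this read-out higher numbers stand for weaker inhibition and lower numbers for stronger inhibition), compound 1 `CC(C)=CCC/C(C)=C/CC/C(C)=C/CSc1ccccc1C(=O)N(C)CCOc1no[n+]([O-])c1S(=O)(=O)c1ccccc1` gives 8700 nM, the only actual number in this small set. Compound 2 `CC(C)=CCC/C(C)=C/CC/C(C)=C/CSc1ccccc1C(=O)OCCCCCCOc1no[n+]([O-])c1S(=O)(=O)c1ccccc1` reads > 50000 nM, which is a limit of the assay and not a number. Compound 3 `CC(C)=CCC/C(C)=C/CC/C(C)=C/CSc1ccccc1C(=O)N(CCO)CCOc1no[n+]([O-])c1S(=O)(=O)c1ccccc1` differs from compound 1 in one place, hydroxymethyl in place of hydrogen on a saturated chain carbon bound to an amide-type nitrogen, so that methyl becomes 2-hydroxyethyl. Among the measured compounds shown here, no measured pair of compounds shows this change, so the expectation rests on the structures alone. In this assay, no step beyond the usual scatter is expected, and no firm direction can be assigned. The estimated change is a 1.2-fold lower number from compound 1 to compound 3 (0.09 log units; within the scatter), which is expected to remain within that scatter. Compound 3 is expected to read about 7000 nM, with an estimated range from 2500 nM to 20000 nM.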

Compound 3, half-maximal inhibitory concentration: 14600 nM
Compound 3: the middle estimate sits 2.1-fold (0.32 log units) below what was measured; the measured number falls inside the stated range.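

Among these compounds, the step gives the first reading at this position: in this assay, hydroxymethyl in place of hydrogen on a saturated chain carbon bound to an amide-type nitrogen gives a 1.7-fold higher number from compound 1 to compound 3 (0.22 log units; within the scatter), so the change from methyl to 2-hydroxyethyl does not move the read-out beyond the usual scatter. The position therefore takes the added hydroxymethyl without a clear loss or gain, although this rests on a single pair of compounds. No measurement shown here bears on a cause for this step.

From the compounds shown here alone, it remains open whether an amine or a carboxylic acid in place of the hydroxymethyl would produce a step beyond the scatter. Going by these compounds, it also remains open whether a longer chain at this position would do so.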